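From oxolan-2-yl to oxolan-3-yl in a rapidly cleared compound

The source may report more compounds than this note shows. Statements on the series, on what has been measured and on what is new or still open speak of the compounds shown alone.

Among the measured compounds shown here, in an in vitro ADME assay on microsomes from liver (Homo sapiens) for metabolic stability, with a stated time of 15 min (a lower number here means slower removal, a higher number faster removal of the compound), compound 1 (`CCc1nn2c(-c3c(C)cc(C)cc3OC)cccc2c1N(CC1CC1)CC1CCCO1`) gives 1230 mL.min-1.g-1 and holds the higher of the two numbers so far. Compound 2 (`CCc1nn2c(-c3c(OC)cc(C)cc3OC)cccc2c1N(CC1CCOCC1)CC1CC1`) gives 440 mL.min-1.g-1 as the lower number. For the measured compounds named here, no two measured compounds differ in one place only, which leaves no measured step to serve as a guide for the next change.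

Compound 3 (`CCc1nn2c(-c3c(C)cc(C)cc3OC)cccc2c1N(CC1CC1)CC1CCOC1`) has the same atoms as compound 1, joined differently: oxolan-3-yl in place of oxolan-2-yl on a saturated chain carbon bound to a nitrogen on an aromatic ring. The group that enters matches the one that leaves in every count, and with nothing measured on this swap, only a small fall within the scatter is expected in this assay as an estimated 1.3-fold lower number from compound 1 to compound 3 (0.11 log units; within the scatter) overall. Compound 3 is estimated at 950 mL.min-1.g-1 with an expected range of 480 mL.min-1.g-1 to 1800 mL.min-1.g-1 for the coming measurement.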

Compound 3, intrinsic clearance in microsomes: 1350 mL.min-1.g-1
For compound 3 the middle estimate is 1.4-fold (0.15 log units) below the measured one; measured number inside the range.
By their numbers in this assay, from the lowest: compound 2; then compounds 1 and 3 (each within the scatter of the next).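

In this assay, oxolan-3-yl in place of oxolan-2-yl gives a 1.1-fold higher number from compound 1 to compound 3 (0.04 log units; within the scatter), a step that stays within the scatter. Among the compounds shown here, this is the first comparison here in which only one place changes, and it shows that, on this saturated chain carbon bound to a nitrogen on an aromatic ring, the two oxolane attachments cannot be told apart in this assay. Nothing available accounts for this result.

Compound 2 differs from compound 1 and compound 3 in more than one place, so its lower number cannot be traced to any single change. The compounds shown also leave open whether a different group in this place, such as a morpholine ring or a carboxylic acid, would move the number beyond the scatter.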